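A few compounds are considered here, and "the series" means these few. Any claim that something is new, unique, unknown or untested is made for them only; others in the source may bear on it.

Compound 1 `Clc1ccc(Cn2cc(CSc3nnc(-c4ccccc4)c(-c4ccccc4)n3)nn2)cc1` — 14700 nM
Compound 2 `Cc1ccc(Cn2cc(CSc3nnc(-c4ccccc4)c(-c4ccccc4)n3)nn2)cc1` — 22600 nM

Both compounds share the same core and differ only in the group on the benzyl ring. In a functional assay on PC-3 cells (Homo sapiens) for antiproliferative activity, read by MTT assay, with a stated time of 48 h (a higher number here means a weaker inhibitor, a lower number a stronger inhibitor), compound 2 stands at one end of the pair of numbers, yet the step of a 1.5-fold higher number from compound 1 to compound 2 (0.19 log units; within the scatter) lies within the scatter, so the two compounds are not separated by this measurement.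

Compound 3 `COc1ccc(Cn2cc(CSc3nnc(-c4ccccc4)c(-c4ccccc4)n3)nn2)cc1` has not yet been measured. Its change from compound 2 is methoxy in place of methyl on an aromatic carbon. Among the compounds with values here, the only measured step that bears on this exchange is the one at the same place, from compound 1 to compound 2, and that step was within the scatter. The expected step of a 1.1-fold lower number from compound 2 to compound 3 (0.05 log units; within the scatter) in this assay is therefore small, with no direction beyond the scatter. Compound 3 is estimated at 20000 nM, with a range from 8000 nM to 50000 nM.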

Compound 3, half-maximal inhibitory concentration: 27500 nM
Estimate against measurement, compound 3: 1.4-fold (0.14 log units) below; the range from low to high includes it.
By their numbers in this assay, from the lowest: compounds 1, 2 and 3 (each within the scatter of the next).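

In this assay, the exchange of methyl for methoxy at this position, para to a large group, adds an oxygen and a hydrogen-bond acceptor, yet a 1.2-fold higher number from compound 2 to compound 3 (0.09 log units; within the scatter) stays within the scatter. The exchange of chloro for methoxy gives the same reading, with a 1.9-fold higher number from compound 1 to compound 3 (0.27 log units; within the scatter) also within the scatter, so chloro, methyl and methoxy at this place are not separated by this measurement, and the third group extends to an oxygen-linked substituent what the first pair showed only for chloro and methyl. Nothing available offers an explanation for this result.

The compounds shown leave open whether an amine, a carboxylic acid or a longer chain at this same place would give a step beyond the scatter. They also leave open whether methoxy would read the same at another place on this ring.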